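Urea series: isopropyl to acetyl on the aryl ring

The compounds below may be only part of what the source reports. "The series", "measured", "known", "first", "only" and "open" are said of these compounds alone.

Measured compounds:
- compound 1 `CC(C)c1cccc(NC(=O)N[C@H](C)c2ccccc2)c1`: 44%
- compound 2 `CC(C)c1cccc(NC(=O)N[C@@H](C)c2ccccc2)c1`: 86%
- compound 3 `C[C@@H](NC(=O)Nc1ccc(C(C)(C)C)cc1)c1ccccc1`: 53%

In an ADME assay on the whole organism with Oryza sativa as the target, tested at 10 uM (a higher number here means a weaker effect of the compound at the concentration tested, a lower number a stronger effect), compound 1 gives 44%, the lowest of the three numbers. Compound 3 is the nearest, and in this assay compound 3 gives 53%, a gap that lies within the scatter, so no order between compound 1 and compound 3 is claimed. Compound 2 is the furthest, and in this assay compound 2 gives 86%. Within the data shown here, the one measured step is a number 42 percentage points higher from compound 1 to compound 2 (beyond the scatter), a large change that rests only on (the fact that compounds 1 and 2 differ only in the configuration as drawn).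

Compound 4 `CC(=O)c1cccc(NC(=O)N[C@H](C)c2ccccc2)c1` is not yet measured. The change from compound 1 to compound 4 is acetyl in place of isopropyl on an aromatic carbon.

Among the measured compounds shown here, no measured step bears on this change: the step from compound 1 to compound 2 concerns configuration alone, and compound 3 differs from compound 1 in more than one place, so only its value can be read beside that of compound 1. With nothing in the series to anchor a shift for an acetyl in place of an isopropyl, no step beyond the scatter is expected in either direction, and the range is kept wide.

For compound 4 the estimate in this assay is 50%, with a range from 25% to 80%, which is expected to mean a step of a number 6 percentage points higher from compound 1 to compound 4 (within the scatter).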

Compound 4, a percentage reported as activity, at one concentration (the size of the read-out at that concentration, not a potency): 73%
For compound 4 the middle estimate is 23 percentage points below the measured one, within the range that was stated.
By their numbers in this assay, from the lowest: compounds 1 and 3 (each within the scatter of the next); then compound 4; then compound 2.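

On an aromatic carbon meta to a large group, acetyl in place of isopropyl gives, in this assay, a number 29 percentage points higher from compound 1 to compound 4 (beyond the scatter), so the substituent at this position, and not only the configuration of the stereocentre, moves the number. The direction is toward a weaker effect at the concentration tested, and the exchange keeps the count of heavy atoms the same while bringing in an oxygen, a double bond outside the aromatic ring and a hydrogen-bond acceptor. Nothing given for these compounds accounts for the step, which stands as an observation on this one pair and cannot be assigned to any one of those differences.

The compounds shown leave open whether the step belongs to acetyl alone or would also appear with another carbonyl-bearing group at this position, such as a carboxylic acid or an amide, or with an amine. They also leave open whether acetyl would behave in the same way with the stereocentre drawn as in compound 2, where the isopropyl compound gives 86%.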